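Series notes: ester-linked aryl sulfides on a shared core

A few compounds are considered here, and "the series" means these few. Any claim that something is new, unique, unknown or untested is made for them only; others in the source may bear on it.

Measured compounds:
compound 1 `C=C1CC[C@@H]2[C@](C)(CO)[C@H](O)CC[C@@]2(C)[C@@H]1C/C=C1/C(=O)OC[C@H]1OC(=O)CSc1ccc(F)cc1` with 14000 nM in a functional assay on PC-3 cells (Homo sapiens) for inhibition, read by MTT assay, with a stated time of 48 h; on this read-out higher numbers stand for weaker inhibition and lower numbers for stronger inhibition
compound 2 `C=C1CC[C@@H]2[C@](C)(CO)[C@H](O)CC[C@@]2(C)[C@@H]1C/C=C1/C(=O)OC[C@H]1OC(=O)CCCSc1ccc(F)cc1` with 12000 nM in this assay

Compound 2 stands within the scatter of compound 1: a 1.2-fold lower number from compound 1 to compound 2 (0.07 log units; within the scatter). Compound 3 `C=C1CC[C@@H]2[C@](C)(CO)[C@H](O)CC[C@@]2(C)[C@@H]1C/C=C1/C(=O)OC[C@H]1OC(=O)CCCSc1cccs1` differs from compound 2 by thiophen-2-yl in place of 4-fluorophenyl on a sulfur. Among the compounds with values here, no measured step changes the aromatic ring on the sulfur; the only step known, a 1.2-fold lower number from compound 1 to compound 2 (0.07 log units; within the scatter), alters the chain and stays within the scatter. No step beyond the scatter is therefore expected in this assay, in either direction. Compound 3 is estimated at 12000 nM, range 5000 nM to 30000 nM, an expected step of no change at the digits printed from compound 2 to compound 3 (within the scatter).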

Compound 3, half-maximal inhibitory concentration: 16000 nM
The estimate for compound 3 lay 1.3-fold (0.12 log units) below the measured number, within the range that was stated.
By their numbers in this assay, from the lowest: compounds 2, 1 and 3 (each within the scatter of the next).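

Within the data shown here, on the sulfur, thiophen-2-yl in place of 4-fluorophenyl gives a 1.3-fold higher number from compound 2 to compound 3 (0.12 log units; within the scatter) in this assay and so provides the first reading on the aromatic ring. Changing the chain and the ring together gives a 1.1-fold higher number from compound 1 to compound 3 (0.06 log units; within the scatter) and likewise leaves the number within the scatter. No measurement at hand offers an explanation for either result.

Still open, going by these compounds, is whether an amine or a carboxylic acid in place of 4-fluorophenyl, or a longer chain, would move the number beyond the scatter. No step shown yet alters the shared core.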